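The source may report more compounds than this note shows. Statements on the series, on what has been measured and on what is new or still open speak of the compounds shown alone.

In a functional assay on HepG2 cells (Homo sapiens) for cytotoxicity, read by MTT assay (a lower number here means a stronger inhibitor, a higher number a weaker inhibitor), compound 3 `O=C1C=C(Nc2ccc(OC(F)(F)F)cc2)C(=O)c2scnc21` reaches only the limit of the assay, > 100 ug/mL, and not a measured number. Compound 1 `Cc1nc2c(s1)C(=O)C=C(Nc1ccc(C(F)(F)F)cc1)C2=O` likewise stops at the limit of > 100 ug/mL. Compound 2 `Cc1nc2c(s1)C(=O)C=C(Nc1cccc(Cl)c1)C2=O` gives 5.7 ug/mL. That boundary is the limit of > 100 ug/mL in this assay, at which 2 of the 3 values shown sit, so compound 3 stands with compound 1 at the edge of what the assay can report, while compound 2 alone shows a number. Compound 4 `O=C1C=C(Nc2ccc(F)cc2)C(=O)c2scnc21` differs from compound 3 by fluoro in place of trifluoromethoxy on an aromatic carbon. For the measured compounds named here, no measured step connects such a pair, so the size of the step is uncertain; a move toward a measurable number, yet not a large one, is expected, placing the step at an at least 2.5-fold lower number from compound 3 to compound 4 (0.39 log units; beyond the scatter). Compound 4 is therefore expected to give about 40 ug/mL, with a range from 8 ug/mL to 150 ug/mL.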

Compound 4, half-maximal inhibitory concentration: 17.9 ug/mL
Compound 4: the middle estimate sits 2.2-fold (0.35 log units) above what was measured; the measured number falls inside the stated range.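

In this assay fluoro in place of trifluoromethoxy on this aromatic carbon gives an at least 5.5-fold lower number from compound 3 to compound 4 (0.74 log units; beyond the scatter) and so turns a limit into a measured number. For the compounds shown here, this is the first sign that a change at this one position can shift the read-out beyond the scatter. On these data alone, the true size of the step remains unknown, since it starts from a limit and is therefore only a minimum: the limit of > 100 ug/mL in this assay, at which 2 of the 4 values shown sit.

As far as these compounds go, how a methoxy group, an amine or a carboxylic acid would behave on the same carbon remains open. A single pair also cannot show whether the swap would act alike on another core, such as that of compound 1.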